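The source may report more compounds than this note shows. Statements on the series, on what has been measured and on what is new or still open speak of the compounds shown alone.

Measured in a functional assay on MGC-803 cells (Homo sapiens) for inhibition, read by MTT assay, with a stated time of 72 h; on this read-out higher numbers stand for weaker inhibition and lower numbers for stronger inhibition:
compound 1 `N#Cc1c(Nc2ccc(Cl)cc2)nc(SCc2cn(Cc3ccccc3Cl)nn2)nc1-c1ccccc1`; compound 1 gives 5850 nM
compound 2 `N#Cc1c(Nc2cccc(Cl)c2)nc(SCc2cn(Cc3ccccc3Cl)nn2)nc1-c1ccccc1`; compound 2 gives 15800 nM
compound 3 `N#Cc1c(Nc2ccccc2F)nc(SCc2cn(Cc3ccccc3Cl)nn2)nc1-c1ccccc1`; compound 3 gives 7580 nM

Compound 3 holds the second highest of the three numbers in this assay. Its nearest neighbour is compound 1, since a 1.3-fold higher number from compound 1 to compound 3 (0.11 log units; within the scatter), which lies within the scatter. Its furthest is compound 2: a 2.1-fold lower number from compound 2 to compound 3 (0.32 log units; beyond the scatter). Going by the values given here, the only other step, a 2.7-fold higher number from compound 1 to compound 2 (0.43 log units; beyond the scatter), also concerns the group on the nitrogen, with 3-chlorophenyl in place of 4-chlorophenyl.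

Compound 4 `Cc1ccccc1Nc1nc(SCc2cn(Cc3ccccc3Cl)nn2)nc(-c2ccccc2)c1C#N` differs from compound 3 in one place: methyl in place of fluoro on an aromatic carbon. Among the compounds with values here, no measured step exchanges fluoro for methyl, and none alters a group ortho to a large group; the three steps all move or swap a halogen on the ring attached to the nitrogen. Of these, the two that touch the 2-fluorophenyl end are small to modest, with a 1.3-fold higher number from compound 1 to compound 3 (0.11 log units; within the scatter) and a 2.1-fold lower number from compound 2 to compound 3 (0.32 log units; beyond the scatter). On that basis a step of a 1.0-fold lower number from compound 3 to compound 4 (0.00 log units; within the scatter) is expected, with no clear direction beyond the scatter. Compound 4 is therefore estimated at 7500 nM, with a range from 3000 nM to 19000 nM.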

Compound 4, half-maximal inhibitory concentration: 7280 nM
The estimate for compound 4 lay 1.0-fold (0.01 log units) above the measured number; measured number inside the range.
By their numbers in this assay, from the lowest: compounds 1, 4 and 3 (each within the scatter of the next); then compound 2.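

In (this assay), methyl in place of fluoro on an aromatic carbon, ortho to a large group, leaves the read-out within the scatter (a 1.0-fold lower number from compound 3 to compound 4 (0.02 log units; within the scatter)), so this pair gives no separation between a carbon-bound group and a halogen at this place. The 2-methylphenyl group also stays within the scatter against 4-chlorophenyl (a 1.2-fold higher number from compound 1 to compound 4 (0.09 log units; within the scatter)) but lies beyond it against 3-chlorophenyl (a 2.2-fold lower number from compound 2 to compound 4 (0.34 log units; beyond the scatter)). Among the four compounds, only compound 2 now stands apart from all the others, with every step to it beyond the scatter.

On these data alone, whether a methoxy group, an amine or a carboxylic acid at this place would also stay within the scatter remains open. Nothing available explains why fluoro and methyl read alike here.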